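This account rests on a few compounds, and the source may have more. Where it says the series, first, only, none or still open, it means among the compounds named here.

Measured so far:
- compound 1, `CC(C)(C)Cc1c(-c2cccc(F)c2F)sc(N)c1C(=O)c1ccc(Cl)cc1`: 1%
- compound 2, `CC(C)(C)Cc1c(-c2ccc(Cl)c(Cl)c2)sc(N)c1C(=O)c1ccc(Cl)cc1`: 1%

In an assay on CHO cells for displacement of a labelled ligand from adenosine receptor A1 (Homo sapiens), read by scintillation counting, tested at 10 uM (on this read-out lower numbers stand for less inhibition and higher numbers for more inhibition at the one concentration tested (going by the name of the read-out)), compound 1 gives 1%, and in the same assay compound 2 gives 1%. For the measured compounds named here, the single measured step, no change at the digits printed from compound 1 to compound 2 (within the scatter), leaves the read-out where it was. Compound 2 thus stands level with compound 1 at the digits shown, its only neighbour, and both sit at the floor of the scale.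

The next compound is compound 3, `Cc1ccccc1-c1sc(N)c(C(=O)c2ccc(Cl)cc2)c1CC(C)(C)C`. Set against compound 2 it carries one alteration:
2-methylphenyl in place of 3,4-dichlorophenyl on an aromatic carbon

Going by the values given here, only one measured step bears on this question, the step from compound 1 to compound 2, which swapped one substituted phenyl for another on the same aromatic carbon and was flat within the scatter. Compound 3 again exchanges the group on that carbon, so the expected step from compound 2 to compound 3 is a number 1 percentage points higher from compound 2 to compound 3 (within the scatter), that is, none beyond the scatter. For compound 3 the estimated inhibition is 2%, with a range from -6% to 12%.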

Compound 3, a percentage reported as inhibition, at one concentration (the size of the read-out at that concentration, not a potency): 1%
The estimate for compound 3 lay 1 percentage points above the measured number; measured number inside the range.
By their numbers in this assay, from the lowest: compounds 1, 2 and 3 (each within the scatter of the next).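

In this assay, putting 2-methylphenyl in place of 3,4-dichlorophenyl on the aromatic carbon next to the ring sulfur gives no change at the digits printed from compound 2 to compound 3 (within the scatter), and putting it in place of 2,3-difluorophenyl gives no change at the digits printed from compound 1 to compound 3 (within the scatter). The earlier compounds shown here carried only halogens on this phenyl ring, whereas the 2-methylphenyl group enters with carbon alone, so the flat read-out at this position now extends to a phenyl ring without chlorine or fluorine. All three groups leave the read-out at the floor of the scale, however, so this series does not separate them, and a flat step here cannot show whether the choice of substituted phenyl matters at all.

The compounds shown leave open whether a group of another kind on this carbon, such as an amine, a carboxylic acid or a longer chain in place of the phenyl ring, would lift the read-out off the floor. They also leave open whether any group at this position would count for more once the neopentyl group or the (4-chlorophenyl)carbonyl group is changed.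

Nothing available accounts for the flat read-out at this position.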